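The compounds below may be only part of what the source reports. "The series", "measured", "known", "first", "only" and "open" are said of these compounds alone.

Of the compounds shown here, three have been read in a functional assay on HeLa cells (Homo sapiens) for cytotoxicity, read by WST assay, with a stated time of 48 h; a higher number here means a weaker inhibitor, a lower number a stronger inhibitor. Compound 1 (`COc1cc(C(c2ccc(O)c(OC)c2)[C@@H](C)[C@@H](C)CO)ccc1O`) gives > 100000 nM, a limit of the assay and not a number. Compound 3 (`COc1cc(C(c2ccc(O)c(OC)c2)[C@@H](C)[C@H](C)CO)ccc1O`) gives > 100000 nM, again only a limit. Compound 2 (`COC[C@H](C(C)C)C(c1ccc(O)c(OC)c1)c1ccc(O)c(OC)c1`) alone gives a number, 76000 nM. Compound 3 thus stands at the limit of > 100000 nM in this assay, at which 2 of the 3 values shown sit.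

The change that leads to compound 4 (`COC[C@@H](C)[C@@H](C)C(c1ccc(O)c(OC)c1)c1ccc(O)c(OC)c1`) is 2-(methoxymethyl)-1-methylpropyl in place of 2-(hydroxymethyl)-1-methylpropyl on a saturated chain carbon bound to two aromatic carbons. Compound 2 also carries a methoxymethyl group in its chain, so two measured steps bear on this change: an at least 1.3-fold lower number from compound 1 to compound 2 (0.11 log units; that floor lies within the scatter), and an at least 1.3-fold higher number from compound 2 to compound 3 (0.11 log units; that floor lies within the scatter). Each of these is only a floor on the size of the step, and neither floor clears the scatter. The remaining pair shows a step that the two limits leave unreadable from compound 1 to compound 3, and it adds no size to the argument, given (the fact that compounds 1 and 3 differ only in the configuration as drawn).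

For the measured compounds named here, the expectation therefore rests on compound 2 at 76000 nM, the one number in hand for a compound with a methoxymethyl group. A small move towards a lower number in this assay is expected, and a reading that stays at the limit is quite possible. The expected change is an at least 1.2-fold lower number from compound 3 to compound 4 (0.09 log units; that floor lies within the scatter). For compound 4 the estimated value is 80000 nM, with an expected range from 40000 nM to 160000 nM.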

Compound 4, half-maximal inhibitory concentration: > 100000 nM
Compound 4: only a limit was reported; the forecaster's own chance of this, stated with the estimate: 45%; middle value at least 1.2-fold (0.09 log units) from the limit.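

With the 2-(methoxymethyl)-1-methylpropyl group on the saturated chain carbon bound to two aromatic carbons, compound 4 reads in this assay only as a limit, so a methoxymethyl group in the chain does not by itself yield a number there: the limit of > 100000 nM in this assay, at which 3 of the 4 values shown sit. Against compound 2, the one compound with a number, the result is an at least 1.3-fold higher number from compound 2 to compound 4 (0.11 log units; that floor lies within the scatter) and so does not separate the two methoxymethyl-bearing chains, 2-(methoxymethyl)-1-methylpropyl and 1-(methoxymethyl)-2-methylpropyl. The steps to compound 4 from the two hydroxymethyl compounds cannot be read, since each has a limit at both ends, and the change from 2-(hydroxymethyl)-1-methylpropyl to 2-(methoxymethyl)-1-methylpropyl therefore has no measurable size here.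

As far as these compounds go, how far compounds 1, 3 and 4 lie past the limit stays open, and with it whether the configuration as drawn or the methoxymethyl group changes the reading at all. Also open, from the compounds shown here alone, is what an amine, a carboxylic acid or a longer chain would read in place of 2-(methoxymethyl)-1-methylpropyl on the saturated chain carbon bound to two aromatic carbons.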